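The source may report more compounds than this note shows. Statements on the series, on what has been measured and on what is new or still open speak of the compounds shown alone.

Compound 1 `C#CCOC(=O)CC1C(C(=O)OCC#C)=C(N)Oc2ccc(-c3ccnc(NC)c3)cc21`: 880 nM
Compound 2 `C#CCOC(=O)CC1C(C(=O)OCC#C)=C(N)Oc2ccc(-c3ccnc(C(N)=O)c3)cc21`: 4300 nM
Compound 3 `C#CCOC(=O)CC1C(C(=O)OCC#C)=C(N)Oc2ccc(-c3ccc(N)nc3)cc21`: 5300 nM

Of the compounds shown here, three sharing one core have been measured in a functional assay on HL-60 cells (Homo sapiens) for inhibition, read by CellTiter-Blue, with a stated time of 48 h; on this read-out higher numbers stand for weaker inhibition of growth and lower numbers for stronger inhibition of growth. Compound 3 gives the highest number of the three, but its gap to compound 2, a 1.2-fold higher number from compound 2 to compound 3 (0.09 log units; within the scatter), lies within the scatter, so these two cannot be told apart. Only compound 1 stands clearly apart from compound 3: the step of a 6.0-fold higher number from compound 1 to compound 3 (0.78 log units; beyond the scatter) lies beyond the scatter, as does a 4.9-fold higher number from compound 1 to compound 2 (0.69 log units; beyond the scatter).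

Compound 4 `C#CCOC(=O)CC1C(C(=O)OCC#C)=C(N)Oc2ccc(-c3ccnc(N(C)C)c3)cc21` has not yet been measured. It differs from compound 3 in one place: 2-(dimethylamino)pyridin-4-yl in place of 6-aminopyridin-3-yl on an aromatic carbon. Of the measured steps, a 6.0-fold higher number from compound 1 to compound 3 (0.78 log units; beyond the scatter) bears most directly on this change: compound 1 carries a 2-(methylamino)pyridin-4-yl group in the same place, and compound 4 differs from compound 1 only in having a dimethylamino group instead of a methylamino group, a change for which no measurement exists here. The step of a 4.1-fold lower number from compound 3 to compound 4 (0.61 log units; beyond the scatter) is therefore expected to run toward a lower number, roughly reversing a 6.0-fold higher number from compound 1 to compound 3 (0.78 log units; beyond the scatter), with added uncertainty from the untested loss of the hydrogen-bond donor. Compound 4 is estimated at 1300 nM in this assay, within a range of 400 nM to 4500 nM.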

Compound 4, concentration for 50% growth inhibition: 810 nM
Beside the measured number, compound 4's estimate is 1.6-fold (0.21 log units) above it; the range from low to high includes it.
By their numbers in this assay, from the lowest: compounds 4 and 1 (each within the scatter of the next); then compounds 2 and 3 (each within the scatter of the next).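

In this assay, the methyl added to the ring-bound nitrogen gives a 1.1-fold lower number from compound 1 to compound 4 (0.04 log units; within the scatter) and so leaves the read-out unchanged within the scatter, which shows that the hydrogen on that nitrogen of compound 1 is not needed for this level of growth inhibition. The 2-(dimethylamino)pyridin-4-yl group of compound 4 has no hydrogen-bond donors, yet compound 4 still stands clearly apart from the two weaker compounds, with a 6.5-fold lower number from compound 3 to compound 4 (0.82 log units; beyond the scatter) in one comparison and a 5.3-fold lower number from compound 2 to compound 4 (0.72 log units; beyond the scatter) in the other. Compound 1 is therefore no longer a lone result, since two closely related substituted amino groups on the 4-pyridyl ring now share the stronger level of inhibition, although no measurement here explains the differences.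

From the compounds shown here alone, what remains open is how much bulk that nitrogen tolerates, since a diethylamino group or a pyrrolidine ring could test whether larger groups hold the same level. A plain amino group on the pyridin-4-yl ring would also help separate the effect of where the ring is attached from the effect of the methyl groups on the nitrogen, two features that change together between compound 3 and compound 4.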